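The compounds below may be only part of what the source reports. "The series", "measured", "known", "first", "only" and "open" are said of these compounds alone.

Measured compounds:
Compound 1, `CS(=O)(=O)c1cc(C(=O)N=C(N)N)ccc1-n1cccn1`, in a functional assay for inhibition of sodium/hydrogen exchanger (Oryctolagus cuniculus) (on this read-out lower numbers stand for stronger inhibition and higher numbers for weaker inhibition), gives 160 nM.
Compound 2, `Cc1cc(-n2cccn2)c(S(C)(=O)=O)cc1C(=O)N=C(N)N`, in this assay gives 25 nM.

Compound 1 stands as the higher of the two numbers; its nearest neighbour is compound 2, reached by a 6.4-fold lower number from compound 1 to compound 2 (0.81 log units; beyond the scatter), where the change is methyl in place of hydrogen on an aromatic carbon. Compound 3, `CS(=O)(=O)c1cc(C(=O)N=C(N)N)ccc1Oc1cccnc1`, has not been measured. Its difference from compound 1 is (pyridin-3-yl)oxy in place of 1H-pyrazol-1-yl on an aromatic carbon. Among the compounds with values here, no measured step bears on this change: the only step on record alters a different position and touches neither of the two groups involved. Within the data shown here, the two values so far therefore say nothing about how replacing the five-membered ring by the six-membered ring carried through oxygen will register. The expectation is a step from compound 1 of about a 1.3-fold higher number from compound 1 to compound 3 (0.10 log units; within the scatter), that is, no change beyond the scatter. Compound 3 is estimated at 200 nM, within the range 60 nM to 700 nM.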

Compound 3, half-maximal inhibitory concentration: 76 nM
The estimate for compound 3 lay 2.6-fold (0.42 log units) above the measured number, within the range that was stated.
By their numbers in this assay, from the lowest: compound 2; then compound 3; then compound 1.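

Within the data shown here, the aromatic carbon ortho to a methylsulfonyl group carries 1H-pyrazol-1-yl in both earlier compounds, so this is the first reading of a change at that carbon. In this assay, (pyridin-3-yl)oxy in place of 1H-pyrazol-1-yl gives a 2.1-fold lower number from compound 1 to compound 3 (0.32 log units; beyond the scatter), which shows that a six-membered aromatic ring joined through oxygen can stand here without the number rising, although the step is only modest. Nothing available explains this step or separates the part played by the oxygen from that of the ring.

On these data alone, it remains open whether the methyl that separates compound 2 from compound 1 would lower the number to a similar extent on compound 3. As far as these compounds go, it is also open how an amine or a plain phenoxy group would register on this same carbon.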